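The compounds below may be only part of what the source reports. "The series", "measured", "known", "first", "only" and "open" are said of these compounds alone.

Compound 1 `COC[C@H](C(C)C)C(c1ccc(O)c(OC)c1)c1ccc(O)c(OC)c1`: 76000 nM
Compound 2 `COc1cc(C(c2ccc(O)c(OC)c2)[C@H](C)C(C)C)ccc1O`: 16000 nM
Compound 3 `COC[C@@H](C(C)C)C(c1ccc(O)c(OC)c1)c1ccc(O)c(OC)c1`: 69000 nM

All three values come from a functional assay on HeLa cells (Homo sapiens) for cytotoxicity, read by WST assay, with a stated time of 48 h; a higher number here means a weaker inhibitor, a lower number a stronger inhibitor. Here compound 3 gives 69000 nM, which places it with compound 1 and well clear of compound 2. The measured step of a 1.1-fold lower number from compound 1 to compound 3 (0.04 log units; within the scatter) reflects (the fact that compounds 1 and 3 differ only in the configuration as drawn), so the drawn configuration at that centre does not register in this assay.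

Compound 4 `COc1cc(C(c2ccc(O)c(OC)c2)[C@@H](C)[C@H](C)CF)ccc1O` is reached from compound 3 by one structural change: 2-(fluoromethyl)-1-methylpropyl in place of 1-(methoxymethyl)-2-methylpropyl on a saturated chain carbon bound to two aromatic carbons. The 1-(methoxymethyl)-2-methylpropyl group leaves, and a 2-(fluoromethyl)-1-methylpropyl group enters on a saturated chain carbon bound to two aromatic carbons.

The closest guides are the steps that remove the methoxy, a 4.8-fold lower number from compound 1 to compound 2 (0.68 log units; beyond the scatter), and its reverse, a 4.3-fold higher number from compound 2 to compound 3 (0.63 log units; beyond the scatter). Both are modest but beyond the scatter. For the measured compounds named here, compound 4 also lacks the methoxy, but it carries fluorine, which no measured compound has, so only part of that shift is anticipated. The expected change is a 2.7-fold lower number from compound 3 to compound 4 (0.42 log units; beyond the scatter), a modest move to a lower number. For compound 4 the estimated value is 26000 nM, with an expected range of 11000 nM to 60000 nM.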

Compound 4, half-maximal inhibitory concentration: 37000 nM
The estimate for compound 4 lay 1.4-fold (0.15 log units) below the measured number; measured number inside the range.
By their numbers in this assay, from the lowest: compound 2; then compounds 4, 3 and 1 (each within the scatter of the next, the first and the last beyond it).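

At the saturated chain carbon bound to two aromatic carbons, the 2-(fluoromethyl)-1-methylpropyl group cannot be told apart from the 1-(methoxymethyl)-2-methylpropyl group of compound 3, as a 1.9-fold lower number from compound 3 to compound 4 (0.27 log units; within the scatter) shows. Compound 4 lacks the methoxy yet does not match compound 2, given a 2.3-fold higher number from compound 2 to compound 4 (0.36 log units; beyond the scatter), while a 2.1-fold lower number from compound 1 to compound 4 (0.31 log units; beyond the scatter) still separates it from the other methoxy isomer, so losing the methoxy does not by itself carry the full shift seen with the 1,2-dimethylpropyl group. Nothing measured in this set gives a reason for these differences.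

The compounds shown leave open whether the configuration at the two stereocentres of the entering group matters, as compound 4 has no stereoisomer among them. They also leave open how a hydroxymethyl, an aminomethyl or a longer chain would behave in this place.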